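Trimethoxyphenyl benzimidazoles: aryl swap from compound 2 to compound 3

The compounds below may be only part of what the source reports. "The series", "measured", "known", "first", "only" and "open" are said of these compounds alone.

Of the compounds shown here, two have been measured. Compound 1 `COc1cc(-n2cnc3ccc(-c4cc(F)ccc4F)cc32)cc(OC)c1OC` gives 6420 nM in a functional assay on MCF7 cells (Homo sapiens) for antiproliferative activity, read by MTT assay, with a stated time of 72 h; a higher number here means a weaker inhibitor, a lower number a stronger inhibitor. Within the data shown here, compound 2 `COc1cc(-n2cnc3ccc(-c4cccc(Cl)c4)cc32)cc(OC)c1OC` gives 3120 nM in the same assay, the lowest of the two numbers, and the only step so far is a 2.1-fold lower number from compound 1 to compound 2 (0.31 log units; beyond the scatter), a modest but real gain from 3-chlorophenyl in place of 2,5-difluorophenyl.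

Compound 3 `COc1cc(-n2cnc3ccc(-c4cccc(C)c4C)cc32)cc(OC)c1OC` is not yet measured. It differs from compound 2 by 2,3-dimethylphenyl in place of 3-chlorophenyl on an aromatic carbon. Among the measured compounds shown here, the single measured step concerns a different pair of aryl groups, so it offers only a weak guide: it shows that changing the substitution pattern on this aryl ring moves the number by a modest amount, and no more. Nothing here separates a chlorine from two methyl groups on the same ring.

The expectation is therefore a step of about a 1.0-fold higher number from compound 2 to compound 3 (0.01 log units; within the scatter), within or at the edge of the scatter, in either direction. Compound 3 is estimated at 3200 nM, with a range from 1400 nM to 7500 nM.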

Compound 3, half-maximal inhibitory concentration: 2150 nM
Compound 3: middle estimate off by 1.5-fold (0.17 log units), on the high side, within the range that was stated.
By their numbers in this assay, from the lowest: compounds 3 and 2 (each within the scatter of the next); then compound 1.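

In this assay, this aromatic carbon now carries an aryl ring with no halogen, and a 1.5-fold lower number from compound 2 to compound 3 (0.16 log units; within the scatter) leaves 2,3-dimethylphenyl and 3-chlorophenyl indistinguishable, so among the compounds shown a chlorine is not required on this ring. The change from 2,5-difluorophenyl, a 3.0-fold lower number from compound 1 to compound 3 (0.48 log units; beyond the scatter), stands beyond the scatter, as does the step from compound 1 to compound 2, which leaves compound 1 as the weakest of the three while the other two cannot be told apart. Nothing available on these compounds offers an explanation for the differences between the aryl groups.

On these data alone, how a plain phenyl, or an amine, a hydroxyl or a carboxylic acid on this aryl ring, would compare with these groups remains open. Also open, as far as these compounds go, is whether a single methyl group on the ring would match the pair in compound 3, and whether the order seen here holds in cell lines other than this one.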